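This account rests on a few compounds, and the source may have more. Where it says the series, first, only, none or still open, it means among the compounds named here.

Of the compounds shown here, three have been tested in a functional assay on BMDM cells (Mus musculus, strain C57BL/6) for inhibition, with a stated time of 2 days (a lower number here means a stronger inhibitor, a higher number a weaker inhibitor), so far. Compound 1, `Cc1cc(NC(=O)Cn2cc(-c3ccc(Cl)cc3)nn2)no1`, gives 1910 nM in this assay. Compound 2, `Cc1cc(NC(=O)Cn2cc(-c3ccc(F)cc3)nn2)no1`, reaches only the limit of the measurement, > 30000 nM, and no number. Compound 3, `O=C(Cn1cc(-c2ccc(F)cc2)nn1)Nc1nc2ccccc2s1`, likewise comes back as the limit > 30000 nM rather than a number.

Compounds 1 and 2 share one core and differ in one place, (chloro in place of fluoro on an aromatic carbon). That change gives an at least 15-fold lower number from compound 2 to compound 1 (1.19 log units; beyond the scatter), so the chloro compound is the clearly stronger inhibitor of this pair; the true size of that step is not known because the limit of > 30000 nM in this assay, at which 2 of the 3 values shown sit, hides how far compound 2 really lies.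

Compound 3 carries a different core from compound 2; the difference between the two cores is not broken down here.

Among the compounds with values here, the compound still to be measured, compound 4, `O=C(Cn1cc(-c2ccc(Cl)cc2)nn1)Nc1nc2ccccc2s1`, is made from compound 3 by chloro in place of fluoro on an aromatic carbon, which is the same change, in the same place, as the one from compound 2 to compound 1. If the change behaves on this core as it did there, a step of about an at least 6.0-fold lower number from compound 3 to compound 4 (0.77 log units; beyond the scatter) is expected, resting on an at least 15-fold lower number from compound 2 to compound 1 (1.19 log units; beyond the scatter), with the caveat that the limit of > 30000 nM in this assay, at which 2 of the 3 values shown sit, makes that earlier step itself only a lower bound. Compound 4 is therefore estimated at 5000 nM in this assay, most likely falling between 1000 nM and 30000 nM.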

Compound 4, half-maximal inhibitory concentration: 130 nM
Estimate against measurement, compound 4: 38-fold (1.59 log units) above; measured number below the stated range.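

In this assay, replacing 4-fluorophenyl with 4-chlorophenyl again gives the stronger inhibitor, with an at least 230-fold lower number from compound 3 to compound 4 (2.36 log units; beyond the scatter), so the direction of the change seen on the core of compound 1 also holds on the core of compound 4, and neither of the two pairs shown goes against it. This does not show that the size of the step carries over from one core to the other, and setting the two steps side by side leaves that question unsettled: the same change on two cores in this assay, an at least 15-fold lower number (1.19 log units; beyond the scatter) from compound 2 to compound 1 and an at least 230-fold lower number (2.36 log units; beyond the scatter) from compound 3 to compound 4; the limit leaves it open whether they differ Each step is only a lower bound, and its true size stays unknown, because compound 2 and compound 3 each give a limit rather than a number: the limit of > 30000 nM in this assay, at which 2 of the 4 values shown sit.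

The compounds shown leave open how other groups would behave in the place of the chloro, for example bromo, methyl or methoxy, and whether the gain from chloro would also appear on a third core. Within the data shown here, they also leave open whether the stronger result of compound 4 would extend beyond this one cell assay, since only two matched pairs on two cores are available here.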